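Swapping the ether group on a glutamate receptor modulator

The source may hold more compounds than are shown below. What is called first, only, known or untested is meant among the compounds shown, and "the series" means these compounds.

Measured so far in a functional assay on CHO cells for positive allosteric modulation of metabotropic glutamate receptor 2 (Homo sapiens), read by scintillation counting and GTPgammaS binding, with a stated time of 30 min; on this read-out lower numbers stand for smaller maximal responses and higher numbers for larger maximal responses:
- compound 1 `COc1cccc(-c2ccn(CCC(C)C)c(=O)c2C#N)c1`: 176%
- compound 2 `CC(C)CCn1ccc(-c2ccc(OCC3CC3)cc2)c(C#N)c1=O`: 192%
- compound 3 `CC(C)CCn1ccc(-c2ccc(OCC3CC3)c(Cl)c2)c(C#N)c1=O`: 206%

Compound 2 stands second of the three. Among the measured compounds shown here, its only single-point neighbour is compound 3, reached by a number 14 percentage points higher from compound 2 to compound 3 (beyond the scatter), a modest gain. Compound 1 sits lower than compound 2 beyond the scatter, and the two differ in the ether part of the aromatic ring.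

Compound 4 `CC(C)CCn1ccc(-c2ccc(Oc3ccccn3)cc2)c(C#N)c1=O` changes the same ether part of compound 2: pyridin-2-yl in place of cyclopropylmethyl on an oxygen on an aromatic ring. For the measured compounds named here, no measured step covers this exact exchange; the chloro step from compound 2 to compound 3 concerns another position, and the values of compound 1 and compound 2 only show that such ether changes have moved the response by a modest amount. A small step is therefore expected, likely a number 7 percentage points lower from compound 2 to compound 4 (within the scatter), with no clear direction. Compound 4 is estimated at 185%, in the range 160% to 210%.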

Compound 4, largest response reached (Emax), in percent of the reference or control that the assay uses: 249%
For compound 4 the middle estimate is 64 percentage points below the measured one; the measured number lies above the stated range.
By their numbers in this assay, from the lowest: compound 1; then compound 2; then compound 3; then compound 4.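

In this assay, putting pyridin-2-yl in place of cyclopropylmethyl on the oxygen gives a number 57 percentage points higher from compound 2 to compound 4 (beyond the scatter) and shows that this group can strongly change the maximal response. Among the compounds shown here, that step is larger than the chloro step, a number 14 percentage points higher from compound 2 to compound 3 (beyond the scatter) on the same parent, so the group on this oxygen offers more room for change than the earlier compounds suggested. Nothing available explains the gain.

From the compounds shown here alone, whether the nitrogen of the new ring matters remains open, and a plain phenyl on the same oxygen would address this. Going by these compounds, it is also open whether the chloro gain would carry over to compound 4.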